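Methyl on the aromatic carbon: carry-over to compound 4

The source may hold more compounds than are shown below. What is called first, only, known or untested is meant among the compounds shown, and "the series" means these compounds.

Measured in a functional assay on the whole organism for antagonist activity, with Mus musculus as the target; a higher number here means that more compound is needed for the effect, a lower number that less compound is needed:
compound 1 `CC1CCC(=O)N1CC#CCn1ccnc1`: compound 1 gives 1.1 mg/kg
compound 2 `Cc1cncn1CC#CCN1C(=O)CCC1C`: compound 2 gives 1.4 mg/kg
compound 3 `CCOC(=O)N(C)C(C)C#CCn1ccnc1`: compound 3 gives 66 mg/kg

Compound 1 and compound 2 share one core, compound 3 carries another; the difference between the two cores is not broken down here. In this assay compound 3 stands well apart from the other two, the gap to compound 2 and to compound 1 lying beyond the scatter.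

Compound 1 and compound 2 differ only by methyl in place of hydrogen on an aromatic carbon, and that step measured a 1.3-fold higher number from compound 1 to compound 2 (0.10 log units; within the scatter), so the methyl change left the number essentially where it was.

Compound 4 `CCOC(=O)N(C)C(C)C#CCn1cncc1C` is not yet measured. It differs from compound 3 by methyl in place of hydrogen on an aromatic carbon, and the place of the change is the same as between compound 1 and compound 2, word for word; it is the same change made on the other core.

Within the data shown here, for compound 4 in this assay a step of about a 1.1-fold higher number from compound 3 to compound 4 (0.06 log units; within the scatter) is expected, because the one measured instance of this change, a 1.3-fold higher number from compound 1 to compound 2 (0.10 log units; within the scatter), stayed within the scatter. Whether the other core answers alike is not known from a single pair, so the range around the expectation is kept wide. Compound 4 is therefore estimated at 75 mg/kg, between 30 mg/kg and 180 mg/kg.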

Compound 4, dose for half-maximal effect: 17.3 mg/kg
For compound 4 the middle estimate is 4.3-fold (0.64 log units) above the measured one; measured number below the stated range.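

In this assay, the change from 1H-imidazol-1-yl to 5-methyl-1H-imidazol-1-yl gives a 3.8-fold lower number from compound 3 to compound 4 (0.58 log units; beyond the scatter), a modest but real shift on this core, whereas on the core of the earlier pair the same change stayed within the scatter. The effect of this methyl therefore does not carry over unchanged from one core to the other in this series, and a step read on one core is a poor stand-in for the step on the other: the same change on two cores in this assay, a 1.3-fold higher number (0.10 log units; within the scatter) from compound 1 to compound 2 and a 3.8-fold lower number (0.58 log units; beyond the scatter) from compound 3 to compound 4, 4.9-fold (0.69 log units) apart, beyond the scatter of two such steps

This rests on one pair per core, so it shows that the outcome of the change depends on the core, but not which part of the difference between the cores is responsible, nor why the methyl counts on one core and not on the other.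

Going by these compounds, whether ethyl or chloro in place of the methyl, on the same aromatic carbon, would also separate the two cores remains open. Also open, on these data alone, is whether a third core, for instance one with an amine in place of the ring amide or the ester end, would follow either pair.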